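Chloro for fluoro on the aryl urea of compound 3

The source may report more compounds than this note shows. Statements on the series, on what has been measured and on what is new or still open speak of the compounds shown alone.

Three aryl ureas built on the shared core have been measured in an ADME assay on the whole organism with Oryza sativa as the target, tested at 10 uM; on this read-out lower numbers stand for a stronger effect and higher numbers for a weaker effect at the one concentration tested. Compound 1 `Cc1ccccc1NC(=O)N[C@@H](C)c1ccccc1` gives 99%, compound 2 `CCc1ccccc1NC(=O)N[C@@H](C)c1ccccc1` gives 95%, and compound 3 `C[C@H](NC(=O)Nc1ccccc1F)c1ccccc1` gives 65%. Compound 3 therefore stands lowest of the three numbers, with compound 2 nearest and compound 1 furthest, both beyond the scatter. The two steps that reach compound 3 are a number 34 percentage points lower from compound 1 to compound 3 (beyond the scatter) and a number 30 percentage points lower from compound 2 to compound 3 (beyond the scatter), while a number 4 percentage points lower from compound 1 to compound 2 (within the scatter) shows that the two alkyl groups do not differ from one another.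

Compound 4 `C[C@H](NC(=O)Nc1ccccc1Cl)c1ccccc1` differs from compound 3 in one place: chloro in place of fluoro on an aromatic carbon. Within the data shown here, the step concerned replaces fluoro with a halogen of larger size, which does not retrace the measured steps exactly; no step with chloro has been measured. Given that both measured steps away from fluoro toward a larger group were large, compound 4 is expected to move upward by a number 15 percentage points higher from compound 3 to compound 4 (beyond the scatter). Compound 4 is estimated at 80%, within 55% to 100%.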

Compound 4, a percentage reported as activity, at one concentration (the size of the read-out at that concentration, not a potency): 106%
Beside the measured number, compound 4's estimate is 26 percentage points below it; measured number above the stated range.
By their numbers in this assay, from the lowest: compound 3; then compounds 2, 1 and 4 (each within the scatter of the next, the first and the last beyond it).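

In this assay, among these compounds, the two halogens do not behave alike on this aromatic carbon: the swap of fluoro for chloro gives a number 41 percentage points higher from compound 3 to compound 4 (beyond the scatter) and so separates them by a large step, which the earlier compounds, holding only fluoro and alkyl groups, could not show. Chloro instead falls in with the alkyl groups, with a number 7 percentage points higher from compound 1 to compound 4 (within the scatter) and only a modest step against ethyl, a number 11 percentage points higher from compound 2 to compound 4 (beyond the scatter) so that among these four compounds the low number belongs to compound 3 alone. No evidence is at hand that bears on why fluoro and chloro part so widely here.

The compounds shown leave open whether another group on this aromatic carbon, such as bromo, hydroxy or methoxy, comes near the number of compound 3. They also leave open whether fluoro keeps that number when the rest of the shared core changes.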